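A few compounds are considered here, and "the series" means these few. Any claim that something is new, unique, unknown or untested is made for them only; others in the source may bear on it.

Measured so far in a functional assay on HEp-2 cells (Homo sapiens) for antiproliferative activity, read by MTT assay, with a stated time of 72 h; on this read-out higher numbers stand for weaker inhibition and lower numbers for stronger inhibition:

Compound 1, `O=c1cc(CSC(=S)N2CCCC2)oc2ccccc12`, gives 9100 nM.
Compound 2, `O=c1cc(CSC(=S)N2CCCC2)oc2cc(Cl)ccc12`, is recorded only as a limit of the assay, > 40000 nM.
Compound 3, `CC(C)N(C(=S)SCc1cc(=O)c2ccc(Cl)cc2o1)C(C)C`, gives 22700 nM.

All three share a core built from a fused two-ring system carrying a thiocarbonyl group, and they differ from one another in two places. Compound 2 differs from compound 1 in this way: hydrogen in place of chloro on an aromatic carbon. That change brought an at least 4.3-fold lower number from compound 2 to compound 1 (0.64 log units; beyond the scatter). The other difference lies at the thiocarbonyl carbon, where compound 3 differs from compound 2 in this way: diisopropylamino in place of pyrrolidin-1-yl on a thiocarbonyl carbon. That change brought an at least 1.7-fold lower number from compound 2 to compound 3 (0.24 log units; that floor lies within the scatter). For compound 2 the assay gives only a limit, (the limit of > 40000 nM in this assay, at which 1 of the 3 values shown sits), so the true size of both steps away from it is not known; they are only floors. Compound 3 gives a higher number than compound 1, which lies beyond the scatter.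

Compound 4, `CC(C)N(C(=S)SCc1cc(=O)c2ccccc2o1)C(C)C`, has not yet been measured. It stands to compound 3 exactly as compound 1 stands to compound 2: hydrogen in place of chloro on an aromatic carbon. The place is the same in both cases, so this is the same change made a second time, now on the core that carries the diisopropylamino group.

Given that compound 1 sits at 9100 nM and that the earlier step was an at least 4.3-fold lower number from compound 2 to compound 1 (0.64 log units; beyond the scatter), the expected step from compound 3 is a 4.5-fold lower number from compound 3 to compound 4 (0.66 log units; beyond the scatter). Within the data shown here, for compound 4 the estimated number in this assay is 5000 nM, with a range from 1500 nM to 16000 nM, resting on the single earlier instance of the same change and on the value of compound 1.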

Compound 4, half-maximal inhibitory concentration: 13600 nM
Beside the measured number, compound 4's estimate is 2.7-fold (0.43 log units) below it; low and high end bracket the measured number.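

In this assay, hydrogen in place of chloro on the core with the diisopropylamino group gives a 1.7-fold lower number from compound 3 to compound 4 (0.22 log units; within the scatter), and diisopropylamino in place of pyrrolidin-1-yl on the core without chloro gives a 1.5-fold higher number from compound 1 to compound 4 (0.17 log units; within the scatter), so neither new step can be told apart from the usual spread of repeated measurements. The earlier steps both start from compound 2, which is known only as a limit of the assay, so the data do not show that removing chloro acts differently on the two cores, and they do not show that it acts alike: the same change on two cores in this assay, an at least 4.3-fold lower number (0.64 log units; beyond the scatter) from compound 2 to compound 1 and a 1.7-fold lower number (0.22 log units; within the scatter) from compound 3 to compound 4; the limit leaves it open whether they differ The same caution applies to the exchange of the two amino groups, which has not been shown either to carry over unchanged or to depend on the chloro group: the same change on two cores in this assay, an at least 1.7-fold lower number (0.24 log units; that floor lies within the scatter) from compound 2 to compound 3 and a 1.5-fold higher number (0.17 log units; within the scatter) from compound 1 to compound 4; the limit leaves it open whether they differ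

The compounds shown leave open what a fluoro, bromo or methoxy group would do on that aromatic carbon, and what a piperidin-1-yl, morpholin-4-yl or diethylamino group would do on the thiocarbonyl carbon. As far as these compounds go, without a true number for compound 2, the size of the chloro change on the core bearing pyrrolidin-1-yl also remains open.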